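The source may hold more compounds than are shown below. What is called first, only, known or untested is meant among the compounds shown, and "the series" means these compounds.

Measured compounds: compound 2, `C[n+]1ccn(CCNS(=O)(=O)C(F)(F)F)c1/C=N/O`, gives in a physicochemical assay for lipophilicity (a higher number here means a more lipophilic compound, a lower number a more polar compound), a value of -1.2. Compound 3, `CC(Cn1cc[n+](C)c1/C=N/O)NS(=O)(=O)C(F)(F)F`, gives in this assay a value of -0.82. Compound 1, `C[n+]1ccn(CCC[n+]2ccc(C(N)=O)cc2)c1/C=N/O`, gives in this assay only a limit of the assay, < -3.

Among the numbers shown, compound 3 stands highest of the two; its nearest neighbour is compound 2, and the step of a number 0.38 log units higher from compound 2 to compound 3 (beyond the scatter) lies beyond the scatter. Compound 1 sits at the limit (the limit of < -3 in this assay, at which 1 of the 3 values shown sits), so it offers no number to compare.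

Compound 4, `CCC(Cn1cc[n+](C)c1/C=N/O)NS(=O)(=O)C(F)(F)F`, has not yet been measured. It differs from compound 3 by methyl in place of hydrogen on a saturated chain carbon, two bonds along the chain from a sulfonamide nitrogen, a change that, cut one bond further out, reads methyl to ethyl.

Going by the values given here, only one measured step bears on this: the addition of a methyl on a saturated chain carbon, a number 0.38 log units higher from compound 2 to compound 3 (beyond the scatter), which gave a modest rise beyond the scatter. Compound 4 carries one more methyl on the same chain, so a rise of similar size is expected for compound 4, a number 0.35 log units higher from compound 3 to compound 4 (beyond the scatter). Compound 4 is therefore expected to give in this assay about -0.47, within a range of -0.85 to -0.1.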

Compound 4, distribution coefficient: -0.42
For compound 4 the middle estimate is 0.05 log units below the measured one, and the stated range covers the measured number.
By their numbers in this assay, from the lowest: compound 2; then compound 3; then compound 4. At a limit, below all of these: compound 1.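

Going by these compounds alone, at this saturated chain carbon, two bonds along the chain from a sulfonamide nitrogen, the change from methyl to ethyl in this assay gave a number 0.40 log units higher from compound 3 to compound 4 (beyond the scatter) and so carried the climb on past the single methyl step, which had been a number 0.38 log units higher from compound 2 to compound 3 (beyond the scatter) on its own. The position has now responded twice: each extension of the chain is a modest step beyond the scatter, both go the same way, and none of the three compounds in this short series goes against that. Read as one change, ethyl in place of hydrogen on that carbon amounts to a number 0.78 log units higher from compound 2 to compound 4 (beyond the scatter) and still counts as modest.

On these data alone, whether the rise goes on with a longer chain such as propyl or butyl, or turns with a hydroxyl group or a carboxylic acid on the same carbon, stays open, as does whether the same methyl step would appear with an amine in place of the sulfonamide. Nothing at hand speaks to what lies behind the rise.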